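This account rests on a few compounds, and the source may have more. Where it says the series, first, only, none or still open, it means among the compounds named here.

Series notes. Three analogues share one core and differ only in the group on an aromatic carbon of one ring. Among the measured compounds shown here, in an assay on liver for inhibition of sterol O-acyltransferase 1 (Rattus norvegicus), using microsomes (on this read-out higher numbers stand for weaker inhibition and lower numbers for stronger inhibition), compound 3 `CC(C)c1cc(Br)cc(C(C)C)c1OC(=O)NS(=O)(=O)Oc1c(C(C)C)cccc1C(C)C` gives 31000 nM, the only plain number recorded so far. Compound 1 `COc1cc(C(C)C)c(OC(=O)NS(=O)(=O)Oc2c(C(C)C)cccc2C(C)C)c(C(C)C)c1` reaches only the limit > 25000 nM in this assay. Compound 2 `CC(C)c1cc([N+](=O)[O-])cc(C(C)C)c1OC(=O)NS(=O)(=O)Oc1c(C(C)C)cccc1C(C)C` reaches only the limit > 50000 nM in this assay. From compound 1 the steps a step that the two limits leave unreadable from compound 1 to compound 2 and a step that the limit leaves unreadable from compound 1 to compound 3 cannot be sized, the value of compound 1 being a limit (the limit of > 25000 nM in this assay, at which 1 of the 3 values shown sits). For the measured compounds named here, the one partly readable step is an at least 1.6-fold lower number from compound 2 to compound 3 (0.20 log units; that floor lies within the scatter), bounded on one side by the limit (the limit of > 50000 nM in this assay, at which 1 of the 3 values shown sits).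

Compound 4 `CC(C)c1cc(Cl)cc(C(C)C)c1OC(=O)NS(=O)(=O)Oc1c(C(C)C)cccc1C(C)C` differs from compound 3 by chloro in place of bromo on an aromatic carbon. Going by the values given here, no measured step swaps one halogen for another; the steps closest to it replace methoxy or nitro, and of those one is unreadable while the other sits at a floor inside the scatter. Expected in this assay is therefore a 1.0-fold lower number from compound 3 to compound 4 (0.01 log units; within the scatter), nothing beyond the scatter. Compound 4 is estimated at 30000 nM, between 12000 nM and 80000 nM.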

Compound 4, half-maximal inhibitory concentration: 42000 nM
The estimate for compound 4 lay 1.4-fold (0.15 log units) below the measured number; the measured number falls inside the stated range.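

Among the compounds shown here, compound 4 supplies a second plain number, so a step at this position, para to a large group, can be sized for the first time: a 1.4-fold higher number from compound 3 to compound 4 (0.13 log units; within the scatter) in this assay, which leaves chloro and bromo not told apart. Against nitro the reading is an at least 1.1-fold lower number from compound 2 to compound 4 (0.07 log units; that floor lies within the scatter), a floor that separates nothing and is bounded on one side by a limit: the limit of > 50000 nM in this assay, at which 1 of the 4 values shown sits. The step from compound 1 cannot be read: the limit of > 25000 nM in this assay, at which 1 of the 4 values shown sits.

From the compounds shown here alone, whether any group at this position moves the number beyond the scatter stays open, for instance an amine, a carboxylic acid or a longer chain. Also open, going by these compounds, is how far compound 1 and compound 2 truly lie from the two halogens, since both are held only as limits.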